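A few compounds are considered here, and "the series" means these few. Any claim that something is new, unique, unknown or untested is made for them only; others in the source may bear on it.

Measured in an ADME assay on HEp-2 cells (Homo sapiens) for cytotoxicity, read by MTT assay, with a stated time of 72 h; a higher number here means a weaker inhibitor, a lower number a stronger inhibitor:
compound 1 `COc1ccc(C2=C(c3cc(OC)c(OC)c(OC)c3)C(=O)C(OC(C)=O)C2)cc1F` gives < 1 ug/mL, which is a limit of the assay rather than a number.
compound 2 `COc1ccc(C2=C(c3cc(OC)c(OC)c(OC)c3)C(=O)CC2O[SiH2]C(C)(C)C)cc1OC` gives > 100 ug/mL, likewise a limit.
compound 3 `COc1cc(C2=C(c3cc(C)c(OC)c(C)c3)C(O)CC2=O)cc(OC)c1OC` gives > 100 ug/mL, likewise a limit.

Compound 1 therefore stands at the limit of < 1 ug/mL in this assay, at which 1 of the 3 values shown sits, while the other two measured compounds sit at the limit of > 100 ug/mL in this assay, at which 2 of the 3 values shown sit. Compound 4 `COc1ccc(C2=C(c3cc(OC)c(OC)c(OC)c3)C(=O)C(OC(C)=O)C2)cc1` has not yet been measured. It differs from compound 1 in one place: hydrogen in place of fluoro on an aromatic carbon. For the measured compounds named here, no pair of measured compounds differs in only one place, so no measured step shows how much such a change moves the read-out. The step expected from this change, a number no lower from compound 1 to compound 4 (the limit leaves the size open), is small, within the usual scatter, leaning if anything toward a weaker inhibitor. Compound 4 is estimated to give about 1 ug/mL, somewhere from 0.3 ug/mL to 3 ug/mL.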

Compound 4, half-maximal inhibitory concentration: 18 ug/mL
Beside the measured number, compound 4's estimate is 18-fold (1.26 log units) below it; the whole stated range lies below it.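

In this assay, replacing the fluoro group, which sits ortho to a methoxy group, with hydrogen gives an at least 18-fold higher number from compound 1 to compound 4 (1.25 log units; beyond the scatter). This is the first one-place change shown, and it reveals that this single position on the 3-fluoro-4-methoxyphenyl ring matters greatly, with the fluoro compound, compound 1, the stronger inhibitor. Compound 1 stands at a limit of the assay rather than a number, so the full size of the step stays open: the limit of < 1 ug/mL in this assay, at which 1 of the 4 values shown sits.

From the compounds shown here alone, whether chloro, a nitrile or a hydroxyl group at this place would match fluoro remains unknown. So does whether the same change would move the read-out as far on another core.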